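Swapping the nitrile for an acetyl group on the shared core

This account rests on a few compounds, and the source may have more. Where it says the series, first, only, none or still open, it means among the compounds named here.

Compound 1, `CC(=O)NCc1cccc(Cn2nc(NS(=O)(=O)c3ccc(Cl)s3)c3ccccc32)c1`, in a physicochemical assay for lipophilicity (a higher number here means a more lipophilic compound, a lower number a more polar compound), gives 3.3.
Compound 2, `CC(=O)NCc1cccc(Cn2nc(NS(=O)(=O)c3ccc(Cl)s3)c3c(O)cccc32)c1`, in this assay gives 2.9.
Compound 3, `CC(=O)NCc1cccc(Cn2nc(NS(=O)(=O)c3ccc(Cl)s3)c3c(C#N)cccc32)c1`, in this assay gives 2.5.

Compound 3 stands lowest of the three numbers: the step of a number 0.80 log units lower from compound 1 to compound 3 (beyond the scatter) and the step of a number 0.40 log units lower from compound 2 to compound 3 (beyond the scatter) both run downward and both lie beyond the scatter, so its place at the bottom is secure.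

Compound 4, `CC(=O)NCc1cccc(Cn2nc(NS(=O)(=O)c3ccc(Cl)s3)c3c(C(C)=O)cccc32)c1`, differs from compound 3 in one place: acetyl in place of cyano on an aromatic carbon. For the measured compounds named here, no measured step involves an acetyl group, so none of the three steps matches this change directly. The steps that do touch the same aromatic carbon, a number 0.40 log units lower from compound 1 to compound 2 (beyond the scatter), a number 0.80 log units lower from compound 1 to compound 3 (beyond the scatter) and a number 0.40 log units lower from compound 2 to compound 3 (beyond the scatter), were all modest, which suggests that a further exchange at this position should also stay modest. With the cyano already giving the lowest number, compound 4 is expected to land close to compound 3, a step of a number 0.10 log units higher from compound 3 to compound 4 (within the scatter), within the scatter. Compound 4 is therefore estimated at 2.6, with a range from 2.2 to 3.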

Compound 4, distribution coefficient: 4.8
Compound 4: middle estimate off by 2.20 log units, on the low side; measured number outside the range, above it.
By their numbers in this assay, from the lowest: compound 3; then compound 2; then compound 1; then compound 4.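

For the compounds shown here, at this aromatic carbon, the read-out in this assay can shift much further than the earlier compounds showed: acetyl in place of cyano gives a number 2.30 log units higher from compound 3 to compound 4 (beyond the scatter), although both groups have the same counts of hydrogen-bond donors and acceptors. The direction can also reverse, since hydroxy and cyano both gave lower numbers than hydrogen, whereas acetyl gives a number 1.50 log units higher from compound 1 to compound 4 (beyond the scatter) and, measured against hydroxy, a number 1.90 log units higher from compound 2 to compound 4 (beyond the scatter). These four compounds therefore show that a single exchange here can raise or lower the number, and that matching donor and acceptor counts do not ensure similar numbers.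

On these data alone, whether the rise is particular to acetyl or would also appear with a carboxylic acid, an amide or a longer chain such as propanoyl remains open. Nothing shown here explains a step of this size.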